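The source may report more compounds than this note shows. Statements on the series, on what has been measured and on what is new or still open speak of the compounds shown alone.

Compound 1 `COc1cc2c(Oc3ccc(NC(=O)c4nn(-c5ccccc5Br)c(=O)c5ccccc45)cc3F)ccnc2cc1OCCCN1CCCC1` serves as the starting point of this small set. In a functional assay on MDA-MB-231 cells (Homo sapiens) for cytotoxicity, read by MTT assay, with a stated time of 72 h (a higher number here means a weaker inhibitor, a lower number a stronger inhibitor), compound 1 gives 1020 nM. Compound 2 `COc1cc2c(Oc3ccc(NC(=O)c4nn(-c5ccc([N+](=O)[O-])cc5)c(=O)c5ccccc45)cc3F)ccnc2cc1OCCCN1CCCC1` differs from it by 4-nitrophenyl in place of 2-bromophenyl on an aromatic nitrogen, and in this assay compound 2 gives 2980 nM; the change made a 2.9-fold higher number from compound 1 to compound 2 (0.47 log units; beyond the scatter). Compound 3 `COc1cc2c(Oc3ccc(NC(=O)c4nn(-c5ccccc5Br)c(=O)c5ccccc45)cc3F)ccnc2cc1OCCCN1CCC(C)CC1` keeps the 2-bromophenyl of compound 1 but carries a different core, the difference between the two cores being (4-methylpiperidin-1-yl in place of pyrrolidin-1-yl on a saturated chain carbon, three bonds along the chain from an oxygen on an aromatic ring). In this assay compound 3 gives 1240 nM, so that the core change made a 1.2-fold higher number from compound 1 to compound 3 (0.08 log units; within the scatter).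

Compound 4 `COc1cc2c(Oc3ccc(NC(=O)c4nn(-c5ccc([N+](=O)[O-])cc5)c(=O)c5ccccc45)cc3F)ccnc2cc1OCCCN1CCC(C)CC1` has not yet been measured. It differs from compound 3 by 4-nitrophenyl in place of 2-bromophenyl on an aromatic nitrogen, the same change that separates compound 1 from compound 2, now made on the core of compound 3; the place of the change is described in the same words for both pairs. Two observations underpin the expectation: the core change itself made only a 1.2-fold higher number from compound 1 to compound 3 (0.08 log units; within the scatter), and the aryl change on the other core made a 2.9-fold higher number from compound 1 to compound 2 (0.47 log units; beyond the scatter). The step expected in this assay is therefore estimated as a 2.9-fold higher number from compound 3 to compound 4 (0.46 log units; beyond the scatter), a step of about the same size as the earlier one. For compound 4 in this assay the estimate is 3600 nM, with a likely range from 1800 nM to 7200 nM, pending the actual measurement.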

Compound 4, half-maximal inhibitory concentration: 4010 nM
Beside the measured number, compound 4's estimate is 1.1-fold (0.05 log units) below it, within the range that was stated.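

In this assay, 4-nitrophenyl in place of 2-bromophenyl on the aromatic nitrogen gave a 3.2-fold higher number from compound 3 to compound 4 (0.51 log units; beyond the scatter), and this change kept its size when carried from one core to the other: the same change on two cores in this assay, a 2.9-fold higher number (0.47 log units; beyond the scatter) from compound 1 to compound 2 and a 3.2-fold higher number (0.51 log units; beyond the scatter) from compound 3 to compound 4, 1.1-fold (0.04 log units) apart, within the scatter of two such steps

Read the other way, 4-methylpiperidin-1-yl in place of pyrrolidin-1-yl gave a 1.3-fold higher number from compound 2 to compound 4 (0.13 log units; within the scatter), so this change stayed within the scatter with either aryl group: the same change on two cores in this assay, a 1.2-fold higher number (0.08 log units; within the scatter) from compound 1 to compound 3 and a 1.3-fold higher number (0.13 log units; within the scatter) from compound 2 to compound 4, 1.1-fold (0.04 log units) apart, within the scatter of two such steps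

Across these four compounds, the two changes therefore behaved as independent steps, with the aryl change setting the larger difference and the core change leaving the number effectively unmoved, but this rests on a single pair of aryl groups, a single pair of cores and one cell assay, and it neither establishes a general rule for the series nor explains why the aryl change has the effect it does.

The compounds shown leave open whether other groups on the aromatic nitrogen, such as an unsubstituted phenyl or a 4-methoxyphenyl, would carry over between these cores in the same way. They also leave open whether the core change would stay as small with a different amine, such as morpholine, or with a longer chain.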